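The compounds below may be only part of what the source reports. "The series", "measured", "known", "first", "only" and "open" are said of these compounds alone.

In a functional assay on the whole organism with Rattus norvegicus as the target, at a dose of 1 mg/kg by the oral route (a lower number here means a weaker effect, a higher number a stronger effect of the compound at the dose given), three compounds have been measured:

compound 1 `COc1cc(C(=O)Nc2nn[nH]n2)nc(-c2ccc(Cl)cc2)c1` gives 0%
compound 2 `COc1cc(C(=O)Nc2nn[nH]n2)nc(-c2ccc(C)cc2)c1` gives 42%
compound 3 `CCc1ccc(-c2cc(OC)cc(C(=O)Nc3nn[nH]n3)n2)cc1` gives 43%

Compound 3 has the highest of the three numbers, but its margin over compound 2 is a number 1 percentage points higher from compound 2 to compound 3 (within the scatter), so the two cannot be told apart; only compound 1 lies clearly apart, as a number 43 percentage points higher from compound 1 to compound 3 (beyond the scatter) shows. The unmeasured compound 4 `COc1cc(C(=O)Nc2nn[nH]n2)nc(-c2ccc(C(C)C)cc2)c1` differs from compound 3 by methyl in place of hydrogen on a saturated chain carbon bound to an aromatic carbon and a saturated chain carbon. Going by the values given here, the step that bears most on this is the one from compound 2 to compound 3, which also added a methyl on a saturated chain carbon bound to an aromatic carbon and gave a number 1 percentage points higher from compound 2 to compound 3 (within the scatter). The large steps of a number 42 percentage points higher from compound 1 to compound 2 (beyond the scatter) and a number 43 percentage points higher from compound 1 to compound 3 (beyond the scatter) both replaced chloro and do not speak to a further growth of the chain. Compound 4 is therefore expected to show a step of about no change at the digits printed from compound 3 to compound 4 (within the scatter) from compound 3, with no change beyond the scatter. Compound 4 is estimated at 43%, in a range from 20% to 65%.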

Compound 4, a percentage reported as inhibition, in the whole organism at one dose (the size of the read-out at that dose, not a potency): 54%
Beside the measured number, compound 4's estimate is 11 percentage points below it; the range from low to high includes it.
By their numbers in this assay, from the lowest: compound 1; then compounds 2 and 3 (each within the scatter of the next); then compound 4.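

In this assay growing the group at this place by one methyl gave a number 1 percentage points higher from compound 2 to compound 3 (within the scatter) when methyl became ethyl, but a number 11 percentage points higher from compound 3 to compound 4 (beyond the scatter) when ethyl became isopropyl, so the same added methyl does not count equally in the two cases. Isopropyl in place of methyl gives a number 12 percentage points higher from compound 2 to compound 4 (beyond the scatter) and so sets compound 4 apart from compound 2 and compound 3, which cannot be told apart from each other. Isopropyl in place of chloro gives a number 54 percentage points higher from compound 1 to compound 4 (beyond the scatter) and leaves compound 4 with the highest number of the four, clear of every other compound.

As far as these compounds go, whether the number would keep rising with tert-butyl, or would hold with a straight propyl chain or a carboxylic acid at this place, stays open. Nothing available explains the difference between the ethyl and isopropyl compounds.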